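From 1-carboxyethoxy to carboxymethoxy: compound 3 to compound 4

The source may report more compounds than this note shows. Statements on the series, on what has been measured and on what is new or still open speak of the compounds shown alone.

Of the compounds shown here, three have been read in a functional assay on HL-60 cells (Homo sapiens) for antiproliferative activity, with a stated time of 72 h (a higher number here means a weaker inhibitor of growth, a lower number a stronger inhibitor of growth), and none gives a number. Compound 1 (`C=C(CC)C(=O)c1ccc(OCC(=O)O)cc1Cl`) reads > 60000 nM, which is a limit of the assay. Compound 2 (`C=C(C)C(=O)c1ccc(OCC(=O)O)cc1C`) reads > 60000 nM, also a limit. Going by the values given here, compound 3 (`C=C(C)C(=O)c1ccc(OC(C)C(=O)O)cc1Cl`) reads > 60000 nM, again a limit, and the series so far sits at the limit of > 60000 nM in this assay, at which 3 of the 3 values shown sit.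

Compound 4 (`C=C(C)C(=O)c1ccc(OCC(=O)O)cc1Cl`) differs from compound 3 by hydrogen in place of methyl on a saturated chain carbon bound to a carbonyl carbon and an oxygen on an aromatic ring, read as 1-carboxyethoxy to carboxymethoxy. No measured step sizes this change, so no shift beyond the scatter is expected in this assay. The estimated step is a number no higher from compound 3 to compound 4 (the limit leaves the size open). For compound 4 the expected value is 60000 nM, with an estimated range of 25000 nM to 100000 nM.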

Compound 4, concentration for 50% growth inhibition: > 60000 nM
Compound 4 ended at the assay's limit; the forecaster's own chance of this, stated with the estimate: 70%; the middle value sits exactly at the limit.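

No new step can be read from compound 3, compound 2 or compound 1 to compound 4, as all four compounds stand at a limit: the limit of > 60000 nM in this assay, at which 4 of the 4 values shown sit. The compounds shown leave open whether any of these single changes alters growth inhibition.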